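A few compounds are considered here, and "the series" means these few. Any claim that something is new, unique, unknown or untested is made for them only; others in the source may bear on it.

Measured compounds and values in this series:

compound 1, `CCOC(=O)CCCCCOc1cccc(CN(C(=O)c2ccc(-c3ccncc3)cc2)C(C)C)c1`; in an ADME assay on HEK293 cells (Homo sapiens) for cytotoxicity, read by CellTiter-Glo and resazurin assay, with a stated time of 72 h (on this read-out lower numbers stand for an effect already at smaller amounts and higher numbers for an effect only at larger amounts of compound), compound 1 gives only a limit, > 26000 nM.
compound 2, `CCOC(=O)CCCCCOc1cccc(CN(C(=O)c2ccc(-c3cccc(-c4ccccc4)c3)cc2)C(C)C)c1`; in this assay compound 2 gives only a limit, > 26000 nM.
compound 3, `CCOC(=O)CCCCCOc1cccc(CN(C(=O)c2ccc(-c3ccc(C(C)=O)s3)cc2)C(C)C)c1`; in this assay compound 3 gives only a limit, > 26000 nM.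

Among the compounds with values here, compound 2 stands at the limit of this assay, and the two further values shown are limits as well; no compound has a number. The next compound is compound 4, `CCOC(=O)CCCCCOc1cccc(CN(C(=O)c2ccc(-c3cccc(OCc4ccccc4)c3)cc2)C(C)C)c1`. The change is benzyloxy in place of phenyl on an aromatic carbon. The measured steps that bear on it are a step that the two limits leave unreadable from compound 1 to compound 2 and a step that the two limits leave unreadable from compound 2 to compound 3; the third, a step that the two limits leave unreadable from compound 1 to compound 3, is no more readable. None of them gives a size or a direction, because of the limit of > 26000 nM in this assay, at which 3 of the 3 values shown sit.

Within the data shown here, the expectation for compound 4 therefore rests on the change alone, with no measured step to set its size, and the working assumption is that compound 4 also sits at the limit of this assay. The step from compound 2 to compound 4 is expected as a step that the limit leaves unreadable from compound 2 to compound 4, which is no readable step. Compound 4 is estimated at 30000 nM, within 14000 nM to 120000 nM.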

Compound 4, half-maximal effective concentration: > 26000 nM
Compound 4 ended at the assay's limit; the forecaster's own chance of this, stated with the estimate: 85%; the middle value does not contradict the limit.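

No step can be read from compound 2 to compound 4 for benzyloxy in place of phenyl, neither in size nor in direction, because both compounds sit at the same limit: the limit of > 26000 nM in this assay, at which 4 of the 4 values shown sit.

The compounds shown leave open at what concentration any of them acts in this assay, and whether the groups exchanged on the shared core make any difference there.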